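Fluoro to trifluoromethyl on a methoxy-bearing ester

The source may hold more compounds than are shown below. What is called first, only, known or untested is meant among the compounds shown, and "the series" means these compounds.

Measured compounds:
compound 1 `CC(=O)Oc1ccc(/C=C/C(=O)OCCSc2nc(-c3ccc(S(C)(=O)=O)cc3)n(-c3ccc(F)cc3)n2)cc1OC(C)=O` gives 14200 nM in a functional assay on B16-F10 cells (Mus musculus) for antiproliferative activity, read by MTT assay, with a stated time of 72 h; a higher number here means a weaker inhibitor, a lower number a stronger inhibitor;
compound 2 `CC(=O)Oc1ccc(/C=C/C(=O)OCCSc2nc(-c3ccc(S(C)(=O)=O)cc3)n(-c3ccc(C(F)(F)F)cc3)n2)cc1OC(C)=O` gives 11500 nM;
compound 3 `COc1cc(/C=C/C(=O)OCCSc2nc(-c3ccc(S(C)(=O)=O)cc3)n(-c3ccc(F)cc3)n2)ccc1OC(C)=O` gives 11200 nM.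

All three numbers come from the same measurement of growth inhibition, and they lie close together. Compound 3 cannot be told apart from compound 1 or from compound 2 on these numbers: its step from compound 1 is a 1.3-fold lower number from compound 1 to compound 3 (0.10 log units; within the scatter), and its gap to compound 2 is smaller still, so it stands level with both.

Compound 4 `COc1cc(/C=C/C(=O)OCCSc2nc(-c3ccc(S(C)(=O)=O)cc3)n(-c3ccc(C(F)(F)F)cc3)n2)ccc1OC(C)=O` is built from compound 3 by one change: trifluoromethyl in place of fluoro on an aromatic carbon. The same exchange has been measured once before, between compound 1 and compound 2, where the result was a 1.2-fold lower number from compound 1 to compound 2 (0.09 log units; within the scatter). That step did not rise above the usual scatter, so it gives no reason to expect a shift of any size in this assay here.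

Compound 4 is therefore expected to give a number close to that of compound 3, with an estimated step of a 1.2-fold lower number from compound 3 to compound 4 (0.07 log units; within the scatter). The estimate for compound 4 is 9500 nM, with a range from 4500 nM to 20000 nM.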

Compound 4, half-maximal inhibitory concentration: 10500 nM
For compound 4 the middle estimate is 1.1-fold (0.04 log units) below the measured one; the measured number falls inside the stated range.
By their numbers in this assay, from the lowest: compounds 4, 3, 2 and 1 (each within the scatter of the next).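

In this assay, the change from 4-fluorophenyl to 4-(trifluoromethyl)phenyl now has a second reading on a different core, and again the step stays small: a 1.1-fold lower number from compound 3 to compound 4 (0.03 log units; within the scatter). Neither reading separates trifluoromethyl from fluoro at this position, and the two readings agree with each other: the same change on two cores in this assay, a 1.2-fold lower number (0.09 log units; within the scatter) from compound 1 to compound 2 and a 1.1-fold lower number (0.03 log units; within the scatter) from compound 3 to compound 4, 1.2-fold (0.06 log units) apart, within the scatter of two such steps. The other change, methyl in place of acetyl on an oxygen on an aromatic ring, also has a second reading, a 1.1-fold lower number from compound 2 to compound 4 (0.04 log units; within the scatter), and its two readings agree as well: the same change on two cores in this assay, a 1.3-fold lower number (0.10 log units; within the scatter) from compound 1 to compound 3 and a 1.1-fold lower number (0.04 log units; within the scatter) from compound 2 to compound 4, 1.2-fold (0.06 log units) apart, within the scatter of two such steps.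

All four compounds stand level in this assay, so these compounds do not show whether any change at either place can move the number beyond the scatter. On these data alone, the groups compared at the ring position are fluoro and trifluoromethyl alone, so the effect of an amine or a carboxylic acid there remains open.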